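The compounds below may be only part of what the source reports. "The series", "measured", "known", "first", "only" and "open" are said of these compounds alone.

Measured so far in a physicochemical assay for lipophilicity, at pH 7.4; a higher number here means a more lipophilic compound, a lower number a more polar compound
Compound 1 `CCc1ccc(N(CC(C)C)S(=O)(=O)c2ccc3c(c2)C(O)CC(C2CCN(S(C)(=O)=O)CC2)O3)cc1` gives 3.22
Compound 2 `CCc1ccc(N(CC(C)C)S(=O)(=O)c2ccc3c(c2)C(O)CC(C2CCOCC2)O3)cc1` gives 4.12
Compound 3 `CCc1ccc(N(CC(C)C)S(=O)(=O)c2ccc3c(c2)C(O)CC(C2CCNCC2)O3)cc1` gives 1.04

Compound 3 has the lowest number of the three, with only hydrogen on the amine nitrogen in its ring. Compound 4 `CCc1ccc(N(CC(C)C)S(=O)(=O)c2ccc3c(c2)C(O)CC(C2CCN(C(=O)C4CCCC4)CC2)O3)cc1` differs from it at that nitrogen, with cyclopentylcarbonyl in place of hydrogen on an amine nitrogen in a ring.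

Two measured steps change the same part of the molecule. The closest, a number 2.18 log units lower from compound 1 to compound 3 (beyond the scatter), is large and swaps methylsulfonyl for that hydrogen. The other, a number 3.08 log units lower from compound 2 to compound 3 (beyond the scatter), is also large and starts from the oxan-4-yl ring. Going by the values given here, both run down to compound 3, so a large rise in this assay is expected when the hydrogen is replaced, although no measured compound carries cyclopentylcarbonyl. The estimated step is a number 3.36 log units higher from compound 3 to compound 4 (beyond the scatter) and it points upward. Compound 4 is expected at 4.4 (estimated range 3.7 to 5.1).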

Compound 4, distribution coefficient: 5.04
The estimate for compound 4 lay 0.64 log units below the measured number; the range from low to high includes it.
By their numbers in this assay, from the lowest: compound 3; then compound 1; then compound 2; then compound 4.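

In this assay, cyclopentylcarbonyl on the amine nitrogen in a ring gives a number 4.00 log units higher from compound 3 to compound 4 (beyond the scatter), the largest step seen so far. Exchanging methylsulfonyl for the same group gives a number 1.82 log units higher from compound 1 to compound 4 (beyond the scatter), so two groups that each replace hydrogen at this nitrogen still end up clearly apart. The lowest and highest numbers in the set now both belong to compounds that differ only at this nitrogen.

Where an acetyl group or a plain ethyl chain on this nitrogen would fall remains open, and nothing available here explains the size of these steps.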